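Swapping the Pyridine for an Alkyl Chain

The compounds below may be only part of what the source reports. "The series", "measured", "known", "first", "only" and "open" are said of these compounds alone.

Compound 1 `CC(C)(C)c1ccc(/C(=C/C(=O)Nc2ccc3c(c2)OCCO3)c2cccnc2)cc1`: 510 nM
Compound 2 `CC(C)(C)c1ccc(/C(=C/C(=O)Nc2ccc3c(c2)OCCO3)c2ccncc2)cc1`: 660 nM

Going by the values given here, in a functional assay on CHO cells for inhibition of transient receptor potential cation channel subfamily V member 1 (Homo sapiens) (on this read-out lower numbers stand for stronger inhibition and higher numbers for weaker inhibition), compound 2 gives 660 nM, the highest of the two numbers measured so far, with compound 1 nearest. Among the compounds with values here, the only measured step, a 1.3-fold higher number from compound 1 to compound 2 (0.11 log units; within the scatter), concerns a different pyridine only. Compound 3 `CC(C)C/C(=C\C(=O)Nc1ccc2c(c1)OCCO2)c1ccc(C(C)(C)C)cc1` instead carries isobutyl in place of pyridin-4-yl on a double-bonded chain carbon bound to an aromatic carbon and a double-bonded chain carbon. Within the data shown here, no measured step replaces a ring with a chain, so that earlier step gives little guidance here. Compound 3 is therefore expected, with wide uncertainty, to lie around 1000 nM, between 250 nM and 4000 nM, meaning an expected step of a 1.5-fold higher number from compound 2 to compound 3 (0.18 log units; within the scatter).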

Compound 3, half-maximal inhibitory concentration: 94 nM
Compound 3: middle estimate off by 11-fold (1.03 log units), on the high side, and the stated range ends above it.
By their numbers in this assay, from the lowest: compound 3; then compounds 1 and 2 (each within the scatter of the next).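

Swapping a pyridine for isobutyl on this double-bonded chain carbon gives a 7.0-fold lower number from compound 2 to compound 3 (0.85 log units; beyond the scatter) and a 5.4-fold lower number from compound 1 to compound 3 (0.73 log units; beyond the scatter) in this assay and so shows that an aromatic ring is not needed here for inhibition. The two pyridines could not be told apart, whereas this chain, with no ring and no hydrogen-bond acceptor, stands clearly apart from both. Nothing measured here explains the change.

Still open, going by these compounds, is whether a shorter ethyl chain, a longer pentyl chain or a saturated cyclohexyl ring would match isobutyl. Also open, on these data alone, is how an amine at the end of such a chain would fare.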